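Changing the amine side chain of compound 2

A few compounds are considered here, and "the series" means these few. Any claim that something is new, unique, unknown or untested is made for them only; others in the source may bear on it.

For the measured compounds named here, in a functional assay on SH-SY5Y cells (Homo sapiens) for cytotoxicity, read by MTT assay, with a stated time of 72 h (on this read-out lower numbers stand for stronger inhibition and higher numbers for weaker inhibition), compound 2 (`O=C1c2c[n+]([O-])c3ccccc3c2C(=O)c2c1c1ccccc1n2CCN1CCCC1`) gives 520 nM and is the only compound here with an exact number. Compound 1 (`O=C1c2c[n+]([O-])c3ccccc3c2C(=O)c2c1c1ccccc1n2Cc1cn(CC(O)CO)nn1`) gives only a limit of the assay (> 1000 nM). Compound 3 (`CC1(C)OC[C@@H](Cn2cc(Cn3c4c(c5ccccc53)C(=O)c3c[n+]([O-])c5ccccc5c3C4=O)nn2)O1`) also gives only a limit (> 1000 nM). The nearest measured side-chain change is an at least 1.9-fold lower number from compound 1 to compound 2 (0.28 log units; that floor lies within the scatter) and gives only a floor for the size of the step. The other step adds nothing on size (a step that the two limits leave unreadable from compound 1 to compound 3). Compound 4 (`CN1CCN(CCCn2c3c(c4ccccc42)C(=O)c2c[n+]([O-])c4ccccc4c2C3=O)CC1`) carries (4-methylpiperazin-1-yl)methyl in place of pyrrolidin-1-yl on a saturated chain carbon, two bonds along the chain from an aromatic nitrogen. The expected change stays within the scatter (a 1.2-fold higher number from compound 2 to compound 4 (0.06 log units; within the scatter)). For compound 4 the estimate is 600 nM (range 220 nM to 1500 nM).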

Compound 4, half-maximal inhibitory concentration: 560 nM
Beside the measured number, compound 4's estimate is 1.1-fold (0.03 log units) above it, and the stated range covers the measured number.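

In this assay, (4-methylpiperazin-1-yl)methyl in place of pyrrolidin-1-yl leaves the two compounds indistinguishable: a 1.1-fold higher number from compound 2 to compound 4 (0.03 log units; within the scatter). So this place on the chain, previously represented by one exact number, can carry the six-membered ring with two nitrogens as well as the five-membered ring. Against compound 1 the result is an at least 1.7-fold lower number from compound 1 to compound 4 (0.25 log units; that floor lies within the scatter), which is only a floor because that compound's value is a limit of the assay: the limit of > 1000 nM in this assay, at which 2 of the 4 values shown sit.

Going by these compounds, the ring and the chain length differ together here, so the effect of each alone stays open. A 3-(pyrrolidin-1-yl)propyl group or a morpholine ring would help separate them.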